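This account rests on a few compounds, and the source may have more. Where it says the series, first, only, none or still open, it means among the compounds named here.

Measured compounds:
- compound 1 `Cc1ccc(C(=O)/C=C/c2ccc3c(c2)B(O)OC3)cc1`: 3700 nM
- compound 2 `Cc1cccc(C(=O)/C=C/c2ccc3c(c2)B(O)OC3)c1`: 2900 nM

Both compounds share one core and differ only in where a methyl group sits on the aryl ring attached to the carbonyl carbon. In a functional assay on SK-OV-3 cells (Homo sapiens) for cytotoxicity, read by MTT assay, with a stated time of 48 h (on this read-out lower numbers stand for stronger inhibition and higher numbers for weaker inhibition), compound 1 gives 3700 nM and compound 2 gives 2900 nM; the step of a 1.3-fold lower number from compound 1 to compound 2 (0.11 log units; within the scatter) lies within the usual scatter, so the two numbers cannot be told apart, and compound 2 merely sits at one end of a pair that is effectively level.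

Compound 3 `Cc1ccc(C(=O)/C=C/c2ccc3c(c2)B(O)OC3)cc1C` keeps everything in compound 2 and adds one group: methyl in place of hydrogen on an aromatic carbon. For the measured compounds named here, the only measured step that bears on this change is the methyl relocation from compound 1 to compound 2, and it stayed within the scatter. On that basis the step of a 1.0-fold higher number from compound 2 to compound 3 (0.01 log units; within the scatter) is expected to stay within the scatter as well. Compound 3 is therefore estimated at 3000 nM, with a range from 1400 nM to 6500 nM.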

Compound 3, half-maximal inhibitory concentration: 1900 nM
Compound 3: the middle estimate sits 1.6-fold (0.20 log units) above what was measured; the range from low to high includes it.
By their numbers in this assay, from the lowest: compounds 3, 2 and 1 (each within the scatter of the next).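

In this assay, a second methyl can sit on an aromatic carbon ortho to a methyl group and para to a large group without a readable change: the step is a 1.5-fold lower number from compound 2 to compound 3 (0.18 log units; within the scatter) and so stays inside the usual noise of the measurement. Reached from the other single-methyl compound, the same pair of methyl groups gives a 1.9-fold lower number from compound 1 to compound 3 (0.29 log units; within the scatter) and this too is within the scatter, so a ring with two methyl groups cannot be told apart from a ring with one. Nothing measured here speaks to what lies behind these numbers.

The compounds shown carry only methyl groups on this ring, so they leave open whether a different group at this carbon, such as a methoxy group, a chlorine atom or an amine, would move the number beyond the scatter. They also leave open how the ring behaves with no methyl group at all.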